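The source may report more compounds than this note shows. Statements on the series, on what has been measured and on what is new or still open speak of the compounds shown alone.

Measured so far in a physicochemical assay for lipophilicity, read by HPLC, at pH 7.5; on this read-out higher numbers stand for higher lipophilicity and lower numbers for lower lipophilicity:

Compound 1, `N#Cc1c(-c2ccc(Br)cc2)nc2cnccc2c1NCC(N)=O`: 1.9
Compound 2, `CCOc1ccccc1-c1ccc(-c2nc3cnccc3c(N[C@H](CC)C(=O)NS(=O)(=O)C3CC3)c2C#N)cc1`: 2.3
Compound 3, `CN(CC(N)=O)c1c(C#N)c(-c2ccc(Br)cc2)nc2cnccc12`: 2.1

Among these three, compound 2 stands highest in this assay. Compound 3, with 2.1, is within the usual scatter of compound 2, whereas compound 1, with 1.9, lies beyond it.

Compound 4, `CCOc1ccccc1-c1ccc(-c2nc3cnccc3c(N[C@H](CC)C(N)=O)c2C#N)cc1`, is the next step from compound 2. The change is hydrogen in place of cyclopropylsulfonyl on an amide-type nitrogen. Among the compounds with values here, the only measured step, a number 0.20 log units higher from compound 1 to compound 3 (within the scatter), concerns a methyl in place of hydrogen on a nitrogen on an aromatic ring and does not bear on this change. Within the data shown here, there is thus no measured step to lean on. Compound 4 is nonetheless expected to read higher than compound 2, an estimated step of a number 0.90 log units higher from compound 2 to compound 4 (beyond the scatter). Compound 4 is estimated at 3.2, with a range from 2.4 to 4.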

Compound 4, distribution coefficient: 3
Compound 4: middle estimate off by 0.20 log units, on the high side; low and high end bracket the measured number.
By their numbers in this assay, from the lowest: compounds 1, 3 and 2 (each within the scatter of the next, the first and the last beyond it); then compound 4.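

In this assay, within the data shown here, hydrogen in place of cyclopropylsulfonyl on an amide-type nitrogen gives a number 0.70 log units higher from compound 2 to compound 4 (beyond the scatter) and so shows that a change at this nitrogen can move the read-out beyond the scatter, which the one earlier step, a number 0.20 log units higher from compound 1 to compound 3 (within the scatter) on a different nitrogen, did not show. No measurement shown here accounts for the size of this step.

Going by these compounds, how a methylsulfonyl or an acetyl group on the same nitrogen would read stays open. So does the reading of a carboxylic acid in place of the carbamoyl.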